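A Shared Core, an Ether Tail Rewritten

A few compounds are considered here, and "the series" means these few. Any claim that something is new, unique, unknown or untested is made for them only; others in the source may bear on it.

Of the compounds shown here, three built on one shared core have been measured in a functional assay on IMR-32 cells with melanin-concentrating hormone receptor 1 (Homo sapiens) as the target, read by fluorescence; on this read-out lower numbers stand for stronger inhibition and higher numbers for weaker inhibition. Compound 1 `Nc1ccc2cccc(OCC3CCCC3)c2n1` gives 2290 nM. Compound 2 `Nc1ccc2cccc(OCC3CC4CCC3C4)c2n1` gives 1730 nM, and compound 3 `Nc1ccc2cccc(OC3CCCCCC3)c2n1` gives 3480 nM. The number of compound 1 lies between those of compound 2 and compound 3, and both gaps fall within the usual scatter of repeated measurements, so on this read-out the three compounds cannot be told apart.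

Compound 4 `COC(C)(C)CCOc1cccc2ccc(N)nc12` has not yet been measured. It differs from compound 1 in one place: 2-methoxy-2-methylpropyl in place of cyclopentyl on a saturated chain carbon bound to an oxygen on an aromatic ring. Going by the values given here, no measured pair shows a step of this kind, so the data give no direct guide to how an open chain in place of a ring behaves on the chain carbon bound to the oxygen on the aromatic ring. The three measured values sit close together and point to no direction. The expected step, a 1.3-fold higher number from compound 1 to compound 4 (0.12 log units; within the scatter), is therefore small and is not thought to reach beyond the scatter in either direction, with the range kept wide for want of a measured precedent. Compound 4 is estimated at 3000 nM, with a range from 1000 nM to 10000 nM.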

Compound 4, half-maximal inhibitory concentration: 4670 nM
For compound 4 the middle estimate is 1.6-fold (0.19 log units) below the measured one; low and high end bracket the measured number.
By their numbers in this assay, from the lowest: compounds 2, 1, 3 and 4 (each within the scatter of the next, the first and the last beyond it).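

In this assay, putting 2-methoxy-2-methylpropyl in place of cyclopentyl on a saturated chain carbon bound to an oxygen on an aromatic ring gives a 2.0-fold higher number from compound 1 to compound 4 (0.31 log units; beyond the scatter), a modest move towards weaker inhibition. Going by these compounds alone, this is the first change at this position that can be read at all, since the three ring-bearing compounds could not be told apart, and it shows that this position does respond to what is attached there, though only modestly. The swap removes the ring and brings in an oxygen with one hydrogen-bond acceptor in a single step, and no measurement at hand gives a reason for the higher number.

The compounds shown leave open whether the ring's removal, the added oxygen or both lie behind the step, a question that an all-carbon open chain such as a plain hexyl group could help separate. Also open, from the compounds shown here alone, is how the position would respond to a chain ending in an amine or a carboxylic acid, or to a longer chain.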